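The source may hold more compounds than are shown below. What is called first, only, known or untested is meant among the compounds shown, and "the series" means these compounds.

Compound 1 `COc1cc(-c2nn(-c3cccc(NC(=O)c4ccc(Cl)c(C(F)(F)F)c4)c3)cc2-c2ccncc2)ccc1Cl` and compound 2 `COc1cc(-c2nn(-c3cccc(NC(=O)Nc4cccc(C(F)(F)F)c4)c3)cc2-c2ccncc2)ccc1Cl` share one core and differ only at the group on the carbonyl carbon. In a functional assay on MDA-MB-231 cells (Homo sapiens) for inhibition, read by sulforhodamine B assay, with a stated time of 48 h (on this read-out lower numbers stand for stronger inhibition of growth and higher numbers for weaker inhibition of growth), compound 1 gives > 32500 nM, which is a limit of the assay rather than a number (the limit of > 32500 nM in this assay, at which 1 of the 2 values shown sits). In this assay, among the compounds with values here, compound 2 gives 2370 nM, the only number so far. The step of an at least 13-fold lower number from compound 1 to compound 2 (1.13 log units; beyond the scatter) puts (3-(trifluoromethyl)phenyl)amino in place of 4-chloro-3-(trifluoromethyl)phenyl and so changes more than the chloro alone. Compound 3 `COc1cc(-c2nn(-c3cccc(NC(=O)Nc4ccc(Cl)c(C(F)(F)F)c4)c3)cc2-c2ccncc2)ccc1Cl` differs from compound 2 by chloro in place of hydrogen on an aromatic carbon. Within the data shown here, no measured step isolates this change. In this assay the step of a 1.6-fold lower number from compound 2 to compound 3 (0.20 log units; within the scatter) is expected to stay within the scatter. Compound 3 is estimated at 1500 nM, between 400 nM and 6000 nM.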

Compound 3, concentration for total growth inhibition: 2600 nM
Beside the measured number, compound 3's estimate is 1.7-fold (0.24 log units) below it; the measured number falls inside the stated range.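

With the aromatic ring otherwise unchanged, chloro in place of hydrogen, ortho to a trifluoromethyl group and para to a large group, shows no change beyond the scatter in this assay (a 1.1-fold higher number from compound 2 to compound 3 (0.04 log units; within the scatter)). With 4-chloro-3-(trifluoromethyl)phenyl held fixed, adding the amino on the carbonyl carbon gives a large step (an at least 12-fold lower number from compound 1 to compound 3 (1.09 log units; beyond the scatter)), so the presence or absence of chloro does not account for the earlier large step. The value for compound 1 in this step is a limit of the assay, not a number.

Open, as far as these compounds go, is whether methoxy or nitrile at the chloro position, or a methyl on the amino nitrogen, would keep this level of growth inhibition.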